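Cyclopropyloxy to tert-butoxy: stability notes

The source may report more compounds than this note shows. Statements on the series, on what has been measured and on what is new or still open speak of the compounds shown alone.

- compound 1 `COc1cc(-c2cnn3cc(OC)c(-c4cnn(C)c4)nc23)ccn1`: 56%
- compound 2 `COc1cn2ncc(-c3ccnc(OC(C)C)c3)c2nc1-c1cnn(C)c1`: 50%
- compound 3 `COc1cn2ncc(-c3ccnc(OC4CC4)c3)c2nc1-c1cnn(C)c1`: 32%

All three values come from an ADME assay on microsomes from liver (Rattus norvegicus) for metabolic stability, with a stated time of 60 min, tested at 1 uM (on this read-out lower numbers stand for a less stable compound and higher numbers for a more stable compound), and the compounds share one core, differing only in the group on the oxygen. Compound 3 at 32% stands lowest of the three, and its gaps to the other two lie beyond the scatter.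

The next step leads to compound 4 `COc1cn2ncc(-c3ccnc(OC(C)(C)C)c3)c2nc1-c1cnn(C)c1`, with tert-butyl in place of cyclopropyl on an oxygen on an aromatic ring.

Among the compounds with values here, three measured steps bear on this change. Isopropyl in place of methyl gave a number 6 percentage points lower from compound 1 to compound 2 (within the scatter) while cyclopropyl in place of methyl gave a number 24 percentage points lower from compound 1 to compound 3 (beyond the scatter) in the same series. Cyclopropyl in place of isopropyl gave a number 18 percentage points lower from compound 2 to compound 3 (beyond the scatter) and this is the closest precedent when read in reverse, given that neither tert-butyl nor isopropyl has a ring. Within the data shown here, no tert-butyl compound has been measured, so the precedent is only partial. A modest rise is therefore expected, somewhat smaller than that reversed step. The estimated change is a number 13 percentage points higher from compound 3 to compound 4 (beyond the scatter) and it carries real uncertainty. In this assay compound 4 is expected at 45% with an estimated range of 27% to 62% around that figure.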

Compound 4, percent of the compound remaining: 61%
Estimate against measurement, compound 4: 16 percentage points below, and the stated range covers the measured number.
By their numbers in this assay, from the lowest: compound 3; then compounds 2, 1 and 4 (each within the scatter of the next, the first and the last beyond it).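

In this assay the low number of compound 3 now reads as particular to the cyclopropyl group rather than to any larger group on this oxygen, since tert-butyl in place of cyclopropyl gives a clear rise (a number 29 percentage points higher from compound 3 to compound 4 (beyond the scatter)). Adding one methyl to the isopropyl group also moves the read-out beyond the scatter (a number 11 percentage points higher from compound 2 to compound 4 (beyond the scatter)), whereas isopropyl in place of methyl stayed within it (a number 6 percentage points lower from compound 1 to compound 2 (within the scatter)), so the open-chain groups do not all behave alike at this position. The two ends of that open-chain set, methyl and tert-butyl, cannot be told apart here (a number 5 percentage points higher from compound 1 to compound 4 (within the scatter)), which means the bulkiest group shown costs nothing on this read-out against the smallest.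

Nothing in the data shown accounts for the gap between the cyclopropyl and tert-butyl groups. From the compounds shown here alone, it remains open how other groups on the same oxygen would fall, such as a cyclobutyl ring, a longer chain like n-butyl or a fluorinated group like trifluoromethyl, and whether this order carries over to a different core.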